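Swapping Propargyl for Phenyl on a Chain

This account rests on a few compounds, and the source may have more. Where it says the series, first, only, none or still open, it means among the compounds named here.

For the measured compounds named here, in a functional assay on A549 cells (Homo sapiens) for inhibition, read by colorimetric assay and MTT assay, with a stated time of 72 h (a lower number here means a stronger inhibitor, a higher number a weaker inhibitor), three compounds have numbers so far: compound 1 `C=CCCCCOc1cc2ccccc2cc1-c1cnc(OCCCCC=C)n1C` reads 16000 nM and compound 2 `C#CCCCCOc1ncc(-c2ccccc2OC)n1C` reads 22000 nM and compound 3 `C=CCCCCOc1ccccc1-c1cnc(OCCOCC=C)n1C` reads 34000 nM as its half-maximal inhibitory concentration. Compound 2 stands in the middle of these three numbers, and its gaps to both others lie within the usual scatter of repeated measurements.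

Compound 4 `COc1ccccc1-c1cnc(OCCCc2ccccc2)n1C` has no number yet. Its difference from compound 2 is phenyl in place of propargyl on a saturated chain carbon, three bonds along the chain from an oxygen on an aromatic ring in one place: phenyl in place of propargyl on a saturated chain carbon, three bonds along the chain from an oxygen on an aromatic ring. Going by the values given here, no measured pair isolates this swap, so the expectation rests only on compound 2 at 22000 nM and its two close neighbours. The step of a 1.2-fold lower number from compound 2 to compound 4 (0.09 log units; within the scatter) is expected to stay within the scatter, with no clear direction. The estimate for compound 4 is 18000 nM within a range of 7000 nM to 45000 nM as its expected reading.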

Compound 4, half-maximal inhibitory concentration: 3000 nM
Estimate against measurement, compound 4: 6.0-fold (0.78 log units) above; the measured number lies below the stated range.
By their numbers in this assay, from the lowest: compound 4; then compounds 1, 2 and 3 (each within the scatter of the next, the first and the last beyond it).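

In this assay the swap of propargyl for phenyl on a saturated chain carbon, three bonds along the chain from an oxygen on an aromatic ring, gives a 7.3-fold lower number from compound 2 to compound 4 (0.87 log units; beyond the scatter) and so shows that the end of this chain is not a neutral spot. For the compounds shown here, the earlier compounds offered no pair differing in one place, so this is the first direct sign that the group here matters, and the six-carbon aromatic ring is accepted in place of the three-carbon alkyne. No measurement in hand explains the drop.

Going by these compounds, whether the lower number belongs to the aromatic ring itself or simply to a group with more heavy atoms remains open. So does what a cyclohexyl ring, an amine or a carboxylic acid would do at this place.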